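Fluoro in Place of Methyl: Expecting Compound 4's Lipophilicity

The compounds below may be only part of what the source reports. "The series", "measured", "known", "first", "only" and "open" are said of these compounds alone.

Of the compounds shown here, three sharing one core have been measured in a physicochemical assay for lipophilicity, read by LC-MS, in phosphate buffer, measured as octanol-water partition, with a stated time of 30 min, at pH 7.4, tested at 200 mM; on this read-out higher numbers stand for higher lipophilicity and lower numbers for lower lipophilicity. Compound 1 `Cn1c(COc2cccc(C(=O)O)c2)nc2ccc(Oc3cc(Cl)ccn3)cc21` gives 1.2. Compound 2 `Cc1cccc(Oc2ccc3nc(COc4cccc(C(=O)O)c4)n(C)c3c2)n1` gives 0.8. Compound 3 `Cc1ccc(Oc2ccc3nc(COc4cccc(C(=O)O)c4)n(C)c3c2)nc1` gives 0.9, the second highest of the three, with compound 2 nearest and compound 1 furthest; both distances stay within the scatter, as a number 0.10 log units higher from compound 2 to compound 3 (within the scatter) and a number 0.30 log units lower from compound 1 to compound 3 (within the scatter) show. For the measured compounds named here, the only step beyond the scatter is a number 0.40 log units lower from compound 1 to compound 2 (beyond the scatter).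

Compound 4 `Cn1c(COc2cccc(C(=O)O)c2)nc2ccc(Oc3ccc(F)cn3)cc21` is not yet measured. It differs from compound 3 in one place: fluoro in place of methyl on an aromatic carbon. Going by the values given here, none of the measured steps exchanges a methyl for a fluoro, so they bear on this change only loosely; they do show that the exchanges already made on this ring moved the read-out by a modest amount at most. In this assay the expected step is therefore a number 0.20 log units lower from compound 3 to compound 4 (within the scatter), a small one, if anything downward and not beyond the scatter. Compound 4 is estimated at 0.7, with a range from 0.3 to 1.1.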

Compound 4, distribution coefficient: 0.6
Compound 4: middle estimate off by 0.10 log units, on the high side; measured number inside the range.
By their numbers in this assay, from the lowest: compounds 4, 2, 3 and 1 (each within the scatter of the next, the first and the last beyond it).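

For the compounds shown here, exchanging methyl for fluoro at this position, on the aromatic carbon para to a large group, is tested directly here for the first time, and in this assay it gives a number 0.30 log units lower from compound 3 to compound 4 (within the scatter) on this single pair, so the exchange cannot be told apart from repeat-to-repeat variation. The 5-fluoropyridin-2-yl group likewise stays close to 6-methylpyridin-2-yl, with a number 0.20 log units lower from compound 2 to compound 4 (within the scatter) as the step, whereas putting it in place of 4-chloropyridin-2-yl gives a number 0.60 log units lower from compound 1 to compound 4 (beyond the scatter) as the largest step among these compounds. Nothing accompanying these numbers explains any of the steps.

Open, going by these compounds, is whether another group at this position, such as methoxy, a nitrile or an amine, would stay as close to methyl and fluoro. Also open, on these data alone, is whether exchanging methyl for fluoro elsewhere on this ring would give a similar step.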